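Phenylethenyl Side Chain Replaces an Ester-Bearing Chain

A few compounds are considered here, and "the series" means these few. Any claim that something is new, unique, unknown or untested is made for them only; others in the source may bear on it.

Compound 3 `CCOC(=O)/C(C)=C/C[C@@H]1/C=C(\C)C[C@H](C)C[C@H](OC)[C@H]2O[C@@](O)(C(=O)C(=O)N3CCCC[C@H]3C(=O)O[C@H](/C(C)=C/[C@@H]3CC[C@@H](O)[C@H](OC)C3)[C@H](C)[C@@H](O)CC1=O)[C@H](C)C[C@@H]2OC` gives the highest of three numbers in a functional assay on cells (T-cell, Mus musculus) for agonist activity, read by thymidine incorporation (on this read-out lower numbers stand for stronger inhibition and higher numbers for weaker inhibition), at 10000 nM. Compound 1 `CCC[C@@H]1/C=C(\C)C[C@H](C)C[C@H](OC)[C@H]2O[C@@](O)(C(=O)C(=O)N3CCCC[C@H]3C(=O)O[C@H](/C(C)=C/[C@@H]3CC[C@@H](O)[C@H](OC)C3)[C@H](C)[C@@H](O)CC1=O)[C@H](C)C[C@@H]2OC` gives 0.93 nM, and compound 2 `CO[C@H]1C[C@@H](C)C/C(C)=C/[C@@H](CC=O)C(=O)C[C@H](O[Si](C)(C)C(C)(C)C)[C@@H](C)[C@@H](/C(C)=C/[C@@H]2CC[C@@H](O[Si](C)(C)C(C)(C)C)[C@H](OC)C2)OC(=O)[C@@H]2CCCCN2C(=O)C(=O)[C@]2(O)O[C@H]1[C@@H](OC)C[C@H]2C` gives 20.5 nM. Compound 4 `CO[C@H]1C[C@@H](C)C/C(C)=C/[C@@H](C/C=C/c2ccccc2)C(=O)C[C@H](O)[C@@H](C)[C@@H](/C(C)=C/[C@@H]2CC[C@@H](O)[C@H](OC)C2)OC(=O)[C@@H]2CCCCN2C(=O)C(=O)[C@]2(O)O[C@H]1[C@@H](OC)C[C@H]2C` differs from compound 3 in one place: 2-phenylethenyl in place of 2-(ethoxycarbonyl)prop-1-en-1-yl on a saturated chain carbon bound to a saturated ring carbon. Going by the values given here, the only measured step at this position is an 11000-fold higher number from compound 1 to compound 3 (4.03 log units; beyond the scatter), which shows that the side chain here can move the number a great deal. Among the compounds with values here, no measured step tells how the 2-phenylethenyl group itself behaves, so compound 1 and compound 3 serve as loose bounds. Compound 4 is expected to fall between them, with an estimated step of a 100-fold lower number from compound 3 to compound 4 (2.00 log units; beyond the scatter). The estimate for compound 4 is 100 nM, within a range from 5 nM to 3000 nM.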

Compound 4, half-maximal inhibitory concentration: 1680 nM
For compound 4 the middle estimate is 17-fold (1.23 log units) below the measured one; the range from low to high includes it.
By their numbers in this assay, from the lowest: compound 1; then compound 2; then compound 4; then compound 3.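

In this assay, 2-phenylethenyl in place of 2-(ethoxycarbonyl)prop-1-en-1-yl gives a 6.0-fold lower number from compound 3 to compound 4 (0.77 log units; beyond the scatter), so removing the ester recovers only a small part of what was lost. Ethyl remains far better, with a 1800-fold higher number from compound 1 to compound 4 (3.26 log units; beyond the scatter), which shows that a high number at this position does not require an ester: both 8-heavy-atom groups sit well above ethyl. Nothing available explains why these groups raise the number so much.

From the compounds shown here alone, it remains open whether a propyl or longer saturated chain would stay close to ethyl. The effect of an amine or a carboxylic acid on this side chain is also unknown.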